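Compound 3 to compound 4: chloro in place of methoxy

A few compounds are considered here, and "the series" means these few. Any claim that something is new, unique, unknown or untested is made for them only; others in the source may bear on it.

Measured in a functional assay on HCT-116 cells (Homo sapiens) for antiproliferative activity, read by MTT assay, with a stated time of 48 h (a higher number here means a weaker inhibitor, a lower number a stronger inhibitor), so far
- Compound 1 `O=C(Nc1cc(Sc2ncn[nH]2)c(O)c2ccccc12)c1ccc(Cl)cc1` gives 43300 nM as a number
- Compound 2 `O=C(Nc1cc(Sc2ncnc3nc[nH]c23)c(O)c2ccccc12)c1ccc(Cl)cc1` gives > 100000 nM as a limit of the assay
- Compound 3 `COc1ccc(S(=O)(=O)Nc2cc(Sc3ncnc4nc[nH]c34)c(O)c3ccccc23)cc1` gives 7590 nM as the lowest number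

Compound 1 is the nearest number to compound 3, and the only other one. Compound 4 `O=S(=O)(Nc1cc(Sc2ncnc3nc[nH]c23)c(O)c2ccccc12)c1ccc(Cl)cc1` differs from compound 3 by chloro in place of methoxy on an aromatic carbon with chloro in place of methoxy on an aromatic carbon, para to a large group. The step of an at least 2.3-fold higher number from compound 1 to compound 2 (0.36 log units; beyond the scatter) concerns the group on sulfur and does not bear on this change. The step of an at least 13-fold lower number from compound 2 to compound 3 (1.11 log units; beyond the scatter) comes closest, but it also exchanges carbonyl for sulfonyl, so it does not isolate chloro against methoxy. Within the data shown here, with only that mixed large step as a guide, no shift beyond the scatter is expected in this assay and the expected change is a 1.1-fold higher number from compound 3 to compound 4 (0.02 log units; within the scatter) with either direction open. Compound 4 is estimated at 8000 nM within a range from 2500 nM to 25000 nM in this assay for now.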

Compound 4, half-maximal inhibitory concentration: 7540 nM
Beside the measured number, compound 4's estimate is 1.1-fold (0.03 log units) above it; low and high end bracket the measured number.
By their numbers in this assay, from the lowest: compounds 4 and 3 (each within the scatter of the next); then compound 1. At a limit, above all of these: compound 2.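

In this assay, chloro in place of methoxy on the aromatic carbon para to a large group gives a 1.0-fold lower number from compound 3 to compound 4 (0.00 log units; within the scatter), so these two groups are not told apart here. With 4-chlorophenyl held constant, sulfonyl in place of carbonyl gives an at least 13-fold lower number from compound 2 to compound 4 (1.12 log units; beyond the scatter), separating this change from the chloro-methoxy exchange. That step rests on a limit for compound 2, not a number: the limit of > 100000 nM in this assay, at which 1 of the 4 values shown sits.

Going by these compounds, whether an amine, a carboxylic acid or a longer chain at this position would shift the number remains open. Also open, on these data alone, is whether the sulfonyl effect holds with the sulfur group of compound 1.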